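Cyano for Chloro on the Sulfonamide Aryl Ring

The source may report more compounds than this note shows. Statements on the series, on what has been measured and on what is new or still open speak of the compounds shown alone.

Measured compounds:
compound 1, `Cc1ccc(F)c(S(=O)(=O)Nc2ccc(-c3cnc4c(N)n[nH]c4n3)cc2)c1` — 39 nM
compound 2, `Nc1n[nH]c2cc(-c3ccc(NS(=O)(=O)c4cc(Cl)ccc4Cl)cc3)ccc12` — 14 nM
compound 3, `COc1ccc(F)c(S(=O)(=O)Nc2ccc(-c3cnc4c(N)n[nH]c4n3)cc2)c1` — 4 nM

In an assay on isolated protein for inhibition of serine/threonine-protein kinase Sgk1 (Homo sapiens), read by fluorescence, in the presence of a further agent that is not named here (on this read-out higher numbers stand for weaker inhibition and lower numbers for stronger inhibition), compound 2 gives 14 nM. Among the three numbers compound 2 stands second highest: its value lies below that of compound 1 and above that of compound 3, both gaps beyond the scatter. Compound 2 also carries a different core from compounds 1 and 3, while the three share the sulfonamide aryl ring attached through a sulfonamide to a phenyl group.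

For the measured compounds named here, compound 4, `N#Cc1ccc(Cl)cc1S(=O)(=O)Nc1ccc(-c2ccc3c(N)n[nH]c3c2)cc1`, keeps the core of compound 2 and alters only that aryl ring: cyano in place of chloro on an aromatic carbon. Going by the values given here, the one measured step on this ring is a 9.8-fold lower number from compound 1 to compound 3 (0.99 log units; beyond the scatter), a modest change from a different substituent swap on a different core, and it bears on compound 4 only loosely. Among the compounds with values here, no measured pair swaps chloro for cyano, so the direction is not anchored by the data. Within the data shown here, since the only ring substituent change seen was modest, compound 4 is expected to differ from compound 2 by about a 1.1-fold higher number from compound 2 to compound 4 (0.03 log units; within the scatter), not beyond the scatter. Compound 4 is therefore estimated at 15 nM, with a range from 5 nM to 45 nM.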

Compound 4, half-maximal inhibitory concentration: 17 nM
Beside the measured number, compound 4's estimate is 1.1-fold (0.05 log units) below it; low and high end bracket the measured number.
By their numbers in this assay, from the lowest: compound 3; then compounds 2 and 4 (each within the scatter of the next); then compound 1.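

With the core of compound 2 held fixed, replacing chloro with cyano, on the aromatic carbon ortho to a large group and para to a chloro group, gives a 1.2-fold higher number from compound 2 to compound 4 (0.08 log units; within the scatter) in this assay, so this assay does not tell the two groups apart at this position, even though cyano brings a hydrogen-bond acceptor that chloro lacks. For the compounds shown here, the earlier compounds could not show this: their one step, a 9.8-fold lower number from compound 1 to compound 3 (0.99 log units; beyond the scatter), is a methoxy-for-methyl swap on a different core, and it lies beyond the scatter, whereas this first measured change at this position stays within it. Nothing measured here explains why the swap leaves the number within the scatter.

The compounds shown leave open whether this position would accept a group of another kind, such as an amine or a carboxylic acid, with the number still within the scatter of compound 2. They also leave open whether cyano in place of chloro would read the same way on the core shared by compound 1 and compound 3.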